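Replacing the Chlorophenyl Sulfone with a Bicyclic Group

The source may report more compounds than this note shows. Statements on the series, on what has been measured and on what is new or still open speak of the compounds shown alone.

Compound 1 `CN1CCC(n2cc(S(=O)(=O)c3cccc(F)c3)c3cccnc32)C1` gives 1.4 nM in an assay on HeLa cells for displacement of a labelled ligand from 5-hydroxytryptamine receptor 6 (Homo sapiens) (on this read-out higher numbers stand for weaker inhibition and lower numbers for stronger inhibition), and compound 2 `CN1CCC(n2cc(S(=O)(=O)c3cccc(Cl)c3)c3cccnc32)C1` gives 1.5 nM in this assay; between them stands the step of a 1.1-fold higher number from compound 1 to compound 2 (0.03 log units; within the scatter). Compound 3 `CCN1CCC(n2cc(S(=O)(=O)c3cccc(Cl)c3)c3cccnc32)C1` gives 3.3 nM, the highest number among the three compounds, reached through the step of a 2.2-fold higher number from compound 2 to compound 3 (0.34 log units; beyond the scatter). Compound 4 `CCN1CCC(n2cc(S(=O)(=O)C3=C(Cl)NC4SC=CN34)c3cccnc32)C1` differs from compound 3 on the sulfonyl sulfur: a group of 9 heavy atoms (5 carbon, 2 nitrogen, 1 sulfur, 1 chlorine; 2 five-membered non-aromatic rings with 2 hetero atoms each) in place of a group of 7 heavy atoms (6 carbon, 1 chlorine; one six-membered aromatic ring of carbon only), on a sulfonyl sulfur. Among the compounds with values here, neither measured step touches this part of the molecule, so no earlier step bears directly on the change; both earlier steps altered only small groups, while this change swaps the whole ring attached to the sulfonyl. The number for compound 4 is therefore expected to rise, with wide uncertainty, by a 9.1-fold higher number from compound 3 to compound 4 (0.96 log units; beyond the scatter). Compound 4 is estimated at 30 nM, within a range from 4 nM to 300 nM.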

Compound 4, inhibition constant: 1.4 nM
The estimate for compound 4 lay 21-fold (1.33 log units) above the measured number; measured number outside the range, below it.
By their numbers in this assay, from the lowest: compounds 1, 4 and 2 (each within the scatter of the next); then compound 3.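

At the sulfonyl sulfur, the whole 3-chlorophenyl ring can be exchanged for a larger group of two non-aromatic five-membered rings without any loss in this assay: the change gives a 2.4-fold lower number from compound 3 to compound 4 (0.37 log units; beyond the scatter). So, in this pair, a six-membered aromatic ring of carbon only is not needed at this position, something the earlier small-group steps could not show. No measurement here explains this gain. On these data alone, whether the chlorine of the entering group matters remains open, as does what an amine or a methoxy group in its place would do.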